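A few compounds are considered here, and "the series" means these few. Any claim that something is new, unique, unknown or untested is made for them only; others in the source may bear on it.

In a functional assay on NCI-H460 cells (Homo sapiens) for positive allosteric modulation, read by MTT assay, with stated times of 2 h and 72 h, tested at 10 uM (a lower number here means a stronger inhibitor, a higher number a weaker inhibitor), compound 1 `COc1cccc(-n2nnc(-c3ccccc3NC(=O)c3ccc(NC(C)=O)cc3)n2)c1` gives 520 nM while compound 2 `COc1cccc(-n2nnc(-c3ccccc3NC(=O)c3ccc(N=[N+]=[N-])cc3)n2)c1` gives 415 nM and compound 3 `COc1cccc(-n2nnc(-c3ccccc3NC(=O)c3ccc(NC(=O)CBr)cc3)n2)c1` gives 250 nM on the same shared core. Of the gaps among them, a 2.1-fold lower number from compound 1 to compound 3 (0.32 log units; beyond the scatter) clears the scatter, whereas a 1.3-fold lower number from compound 1 to compound 2 (0.10 log units; within the scatter) and a 1.7-fold lower number from compound 2 to compound 3 (0.22 log units; within the scatter) do not, so compound 3 stands apart from only one of the other two.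

Compound 4 `COc1cccc(-n2nnc(-c3ccccc3NC(=O)Nc3ccc([N+](=O)[O-])cc3)n2)c1` differs from compound 3 by a larger exchange, with (4-nitrophenyl)amino in place of 4-(((bromomethyl)carbonyl)amino)phenyl on a carbonyl carbon. Going by the values given here, no measured step covers this whole exchange, so the three small steps are only a loose guide. The bromo leaves with this exchange, and the two measured compounds without it, compound 1 at 520 nM and compound 2 at 415 nM, offer the nearest reference. In this assay a modest move toward a higher number is therefore expected, estimated as a 1.8-fold higher number from compound 3 to compound 4 (0.26 log units; within the scatter) and not clearly separable from the scatter. Compound 4 is estimated at 450 nM with an expected range from 130 nM to 1500 nM and that width allows for the unmeasured exchange.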

Compound 4, half-maximal inhibitory concentration: 113 nM
For compound 4 the middle estimate is 4.0-fold (0.60 log units) above the measured one; measured number below the stated range.
By their numbers in this assay, from the lowest: compound 4; then compounds 3, 2 and 1 (each within the scatter of the next, the first and the last beyond it).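

In this assay, putting (4-nitrophenyl)amino on the carbonyl carbon gives a 2.2-fold lower number from compound 3 to compound 4 (0.34 log units; beyond the scatter), a 3.7-fold lower number from compound 2 to compound 4 (0.56 log units; beyond the scatter) and a 4.6-fold lower number from compound 1 to compound 4 (0.66 log units; beyond the scatter), so all three earlier groups are surpassed by a margin beyond the scatter. The bromo group of compound 3 is therefore not needed for the strongest inhibition in this set, since compound 4 has none and still gives the lowest number. Nothing shown here accounts for this gain.

From the compounds shown here alone, the exchange changes two things at once: an amino group now links the aromatic ring to the carbonyl carbon, and a nitro group replaces the earlier ring substituents, so the share of each remains unknown. Going by these compounds, it also remains open how an amine or a carboxylic acid in place of the nitro group would read on the same link.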